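This account rests on a few compounds, and the source may have more. Where it says the series, first, only, none or still open, it means among the compounds named here.

Working notes on the series, where the shared core stays fixed and the group on a saturated chain carbon bound to a sulfur varies. In a functional assay on MCF7 cells (Homo sapiens) for inhibition, read by MTT assay, with a stated time of 72 h (a higher number here means a weaker inhibitor, a lower number a stronger inhibitor), compound 1 `Cc1cc(Nc2cc(-c3ccccc3)[nH]n2)n2nc(SCc3c(Cl)cccc3Cl)nc2n1` gives 3230 nM, compound 2 `C#CCSc1nc2nc(C)cc(Nc3cc(-c4ccccc4)[nH]n3)n2n1` gives 21800 nM, and compound 3 `Cc1cc(Nc2cc(-c3ccccc3)[nH]n2)n2nc(SCc3ccc(C(F)(F)F)cc3)nc2n1` gives 4820 nM. Compound 3 is level with compound 1, with a 1.5-fold higher number from compound 1 to compound 3 (0.17 log units; within the scatter), and stands well clear of compound 2, with a 4.5-fold lower number from compound 2 to compound 3 (0.66 log units; beyond the scatter).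

Compound 4 `Cc1cc(Nc2cc(-c3ccccc3)[nH]n2)n2nc(SCC3CC3)nc2n1` carries cyclopropyl in place of 4-(trifluoromethyl)phenyl on a saturated chain carbon bound to a sulfur. For the measured compounds named here, no cyclopropyl compound has been measured, so the closest guide is compound 2, the only measured compound with a non-aromatic group there. The relevant steps are a 6.7-fold higher number from compound 1 to compound 2 (0.83 log units; beyond the scatter) and a 4.5-fold lower number from compound 2 to compound 3 (0.66 log units; beyond the scatter), and both link it to an aromatic partner. A modest move to a higher number is therefore expected in this assay, slightly smaller than those steps. The expected step is a 2.9-fold higher number from compound 3 to compound 4 (0.46 log units; beyond the scatter). For compound 4 the estimated value is 14000 nM, with an expected range of 6500 nM to 30000 nM.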

Compound 4, half-maximal inhibitory concentration: > 50000 nM
Compound 4: only a limit was reported (the forecaster's own chance of this, stated with the estimate: 8%); at least 3.5-fold (0.55 log units) between middle value and limit.
By their numbers in this assay, from the lowest: compounds 1 and 3 (each within the scatter of the next); then compound 2. At a limit, above all of these: compound 4.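

In this assay, compound 4 gives only a limit and not a number: the limit of > 50000 nM in this assay, at which 1 of the 4 values shown sits. Cyclopropyl in place of the aromatic groups on a saturated chain carbon bound to a sulfur gives an at least 10-fold higher number from compound 3 to compound 4 (1.01 log units; beyond the scatter) and an at least 15-fold higher number from compound 1 to compound 4 (1.18 log units; beyond the scatter), and both exceed every step among the earlier compounds. Cyclopropyl in place of ethynyl also gives an at least 2.2-fold higher number from compound 2 to compound 4 (0.36 log units; beyond the scatter), so the two non-aromatic groups are not interchangeable at this position, and the absence of an aromatic ring does not alone set the level reached.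

Going by these compounds, it remains open whether a larger saturated ring such as cyclohexyl, or an unsubstituted phenyl, would return to the level shared by compound 1 and compound 3. On these data alone, the true size of all three new steps also stays unknown, since each rests on a limit.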